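Swapping Chloro for Methoxy in a Nitrofuran Amide Series

The source may report more compounds than this note shows. Statements on the series, on what has been measured and on what is new or still open speak of the compounds shown alone.

Compound 1 `CC(C)(NC(=O)c1ccc([N+](=O)[O-])o1)c1ccccc1` gives > 180000 nM, which is a limit of the assay.
Compound 2 `O=C(Nc1cc2ccccc2o1)c1ccc([N+](=O)[O-])o1` gives 40000 nM.
Compound 3 `CC(C)(NC(=O)c1ccc([N+](=O)[O-])o1)c1ccc(Cl)cc1` gives 81000 nM.

These three amides share a nitrofuran carbonyl core and were tested in an ADME assay on Vero cells (Chlorocebus sabaeus) for cytotoxicity, read by MTT assay, with a stated time of 48 h; on this read-out lower numbers stand for higher toxicity in this test and higher numbers for lower toxicity in this test. Among the two proper numbers, compound 3 stands highest, so it is the less toxic of the two; compound 2 sits nearest with its lower value. Compound 1 is known only as a limit, (the limit of > 180000 nM in this assay, at which 1 of the 3 values shown sits), so it cannot be placed exactly.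

Only one measured step connects two of these compounds by a single change: an at least 2.2-fold lower number from compound 1 to compound 3 (0.34 log units; beyond the scatter). That step shows that adding a chloro group moved the number down, beyond the scatter.

Compound 4 `COc1ccc(C(C)(C)NC(=O)c2ccc([N+](=O)[O-])o2)cc1` is the next compound, differing from compound 3 by methoxy in place of chloro on an aromatic carbon. Among the compounds with values here, no measured step here shows what a methoxy group does, so the expectation rests on the single chloro step alone: removing chloro would likely push the number back up, while the entering methoxy is untested. A modest rise is expected, a 1.5-fold higher number from compound 3 to compound 4 (0.17 log units; within the scatter), with real uncertainty in both directions. Compound 4 is therefore estimated at 120000 nM, within a range from 50000 nM to 300000 nM.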

Compound 4, half-maximal cytotoxic concentration: 82000 nM
Compound 4: middle estimate off by 1.5-fold (0.17 log units), on the high side; low and high end bracket the measured number.
By their numbers in this assay, from the lowest: compound 2; then compounds 3 and 4 (each within the scatter of the next). At a limit, above all of these: compound 1.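

In this assay, trading chloro for methoxy on this aromatic carbon, para to a large group, leaves the read-out effectively unchanged, even though methoxy brings a hydrogen-bond acceptor and chloro brings none: a 1.0-fold higher number from compound 3 to compound 4 (0.01 log units; within the scatter). Measured against hydrogen at the same place, methoxy gives an at least 2.1-fold lower number from compound 1 to compound 4 (0.34 log units; beyond the scatter), so the step seen earlier with chloro is no longer a single case, and two different groups now stand apart from the unsubstituted compound by more than the scatter. The true size of both steps stays unknown, as compound 1 is known only as a limit: the limit of > 180000 nM in this assay, at which 1 of the 4 values shown sits.

The compounds shown leave open whether the same place would tolerate a very different group just as well, such as an amine, a carboxylic acid or a longer chain like butoxy, or whether chloro and methoxy only happen to match. They also leave open whether this swap would give the same result on another core, such as that of compound 2.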